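Carbonyl substituent change from compound 2 to compound 4

The source may hold more compounds than are shown below. What is called first, only, known or untested is meant among the compounds shown, and "the series" means these compounds.

The series is followed in a functional assay on SK-BR-3 cells (Homo sapiens) for antiproliferative activity, read by MTT assay, with a stated time of 72 h; on this read-out lower numbers stand for stronger inhibition and higher numbers for weaker inhibition. Among the compounds with values here, compound 1 `Cc1cc(NCCN(C)C)nc2ccc(NC(=O)c3ccc(Cl)c(Cl)c3)cc12` gives 6670 nM and compound 3 `Cc1cc(N2CCN(C(C)C)CC2)nc2ccc(NC(=O)c3ccc(Cl)c(Cl)c3)cc12` gives 6680 nM; the one step between them, a 1.0-fold higher number from compound 1 to compound 3 (0.00 log units; within the scatter), leaves the read-out unchanged. Compound 2 `CCN1CCN(c2cc(C)c3cc(NC(=O)c4ccc(Cl)cc4)ccc3n2)CC1` gives 3020 nM, the lowest number of the three, with both other compounds standing beyond the scatter above it. Compound 4 `CCN1CCN(c2cc(C)c3cc(NC(=O)c4ccc[nH]4)ccc3n2)CC1` differs from compound 2 by 1H-pyrrol-2-yl in place of 4-chlorophenyl on a carbonyl carbon. Within the data shown here, no measured step touches the group on the carbonyl carbon: the single step recorded, from compound 1 to compound 3, alters the amine on the aromatic carbon, and compound 2 differs from each of those two in two places at once, so no single step can be read off for it. The change in compound 4 is therefore without precedent in this set, and the expectation in this assay is uncertain. The expected step of a 1.7-fold higher number from compound 2 to compound 4 (0.22 log units; within the scatter) is taken as modest, toward a higher number, with wide uncertainty in both directions. Compound 4 is estimated at 5000 nM, between 1500 nM and 20000 nM.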

Compound 4, half-maximal inhibitory concentration: 13200 nM
Beside the measured number, compound 4's estimate is 2.6-fold (0.42 log units) below it, and the stated range covers the measured number.
By their numbers in this assay, from the lowest: compound 2; then compounds 1, 3 and 4 (each within the scatter of the next).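

In this assay, within the data shown here, the group on the carbonyl carbon now has a step of its own: 1H-pyrrol-2-yl in place of 4-chlorophenyl gives a 4.4-fold higher number from compound 2 to compound 4 (0.64 log units; beyond the scatter) and so moves the read-out beyond the scatter, whereas the only earlier step, at the amine on the aromatic carbon, gave a 1.0-fold higher number from compound 1 to compound 3 (0.00 log units; within the scatter) and left it unchanged. The exchange replaces a six-membered carbon ring bearing chlorine with a five-membered ring holding one hydrogen-bond donor, and this single pair cannot separate those differences. As far as these compounds go, whether the higher number follows the loss of the chlorine or the change of ring stays open; a plain phenyl or a 1-methylpyrrol-2-yl on the carbonyl carbon would address that. Comparisons of compound 4 with compound 1 or compound 3 cannot be read, as those pairs differ in more than one place. No measurement offered here explains the step.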